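The compounds below may be only part of what the source reports. "The series", "measured", "known", "first", "only" and "open" are said of these compounds alone.

Measured so far:
Compound 1, `Cc1ccc(Nc2cc(NC(=O)Nc3c(Cl)cccc3Cl)ncn2)cc1F` — in a functional assay on NCI-H226 cells (Homo sapiens) for inhibition, read by MTT assay, with a stated time of 48 h, tested at 10 uM (on this read-out lower numbers stand for less inhibition and higher numbers for more inhibition at the one concentration tested (going by the name of the read-out)), compound 1 gives 40.7%.
Compound 2, `COc1cc(NC(=O)Nc2cc(Nc3ccc(F)c(Cl)c3)ncn2)cc(OC)c1` — in this assay compound 2 gives 36.7%.

Compound 2 has the lower of the two numbers, yet the gap to compound 1 lies within the usual scatter of repeated measurements, so the two cannot be told apart on this read-out. Compound 3, `COc1cc(NC(=O)Nc2cc(Nc3ccc(OC)c(C)c3)ncn2)cc(OC)c1`, has not yet been measured in this assay. It differs from compound 2 in one place: 4-methoxy-3-methylphenyl in place of 3-chloro-4-fluorophenyl on a nitrogen on an aromatic ring. Going by the values given here, no pair of measured compounds shows what such a change does, and the two numbers in hand sit close together, so there is no footing for a large step in either direction. The step expected from compound 2 to compound 3 is a number 3.7 percentage points lower from compound 2 to compound 3 (within the scatter), no bigger than the scatter. Compound 3 is expected to give about 33% in this assay, with a range from 15% to 55%.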

Compound 3, a percentage reported as inhibition, at one concentration (the size of the read-out at that concentration, not a potency): 39.7%
Compound 3: middle estimate off by 6.7 percentage points, on the low side; low and high end bracket the measured number.
By their numbers in this assay, from the lowest: compounds 2, 3 and 1 (each within the scatter of the next).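

Putting 4-methoxy-3-methylphenyl in place of 3-chloro-4-fluorophenyl on a nitrogen on an aromatic ring gives a number 3 percentage points higher from compound 2 to compound 3 (within the scatter) in this assay. Going by these compounds alone, this is the first measured pair that differs in this one place, and it shows that these two substituted phenyl groups cannot be told apart on this read-out, even though one carries chlorine and fluorine and the other carries methoxy and methyl. No measurement on hand explains this result.

The compounds shown leave open whether any group at this position would give a clearly different number, such as a phenyl ring carrying an amine or a carboxylic acid, or a longer chain in place of the ring. They also leave open whether the same swap would give a similar result with the other urea substituent, the 2,6-dichlorophenyl group of compound 1.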